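The source may report more compounds than this note shows. Statements on the series, on what has been measured and on what is new or still open speak of the compounds shown alone.

Measured so far in a functional assay on 143B cells (Homo sapiens) for inhibition, read by MTT assay, with a stated time of 72 h; a lower number here means a stronger inhibitor, a higher number a weaker inhibitor:

compound 1 `Cc1ccc(NC(=O)CCC(=O)OCCCCCCSc2ccc([N+](=O)[O-])c3nonc23)cc1`: 3250 nM
compound 2 `O=C(CCC(=O)OCCCCCCSc1ccc([N+](=O)[O-])c2nonc12)NCCN1CCCC1`: 5580 nM

Compound 1 holds the lowest of the two numbers; its nearest neighbour is compound 2, and the step of a 1.7-fold higher number from compound 1 to compound 2 (0.23 log units; within the scatter) lies within the scatter, so the two cannot be ordered on the numbers shown. Compound 3 `O=C(CCC(=O)N1CCOCC1)OCCCCCCSc1ccc([N+](=O)[O-])c2nonc12` is the next member to be measured in this assay. It differs from compound 1 as follows: morpholin-4-yl in place of (4-methylphenyl)amino on a carbonyl carbon. For the measured compounds named here, the only measured step that bears on this change is a 1.7-fold higher number from compound 1 to compound 2 (0.23 log units; within the scatter), where the 4-methylphenyl on the amide-type nitrogen was exchanged for an aliphatic amine-bearing chain without moving the number beyond the scatter. Compound 3 removes the same aryl group and the amide hydrogen with it, so a similar small step is expected, if anything towards a higher number: a 1.5-fold higher number from compound 1 to compound 3 (0.19 log units; within the scatter). Compound 3 is therefore estimated at 5000 nM in this assay, with a range of 2000 nM to 12500 nM.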

Compound 3, half-maximal inhibitory concentration: 1530 nM
For compound 3 the middle estimate is 3.3-fold (0.51 log units) above the measured one, outside the stated range (below it).
By their numbers in this assay, from the lowest: compound 3; then compounds 1 and 2 (each within the scatter of the next).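

In this assay, morpholin-4-yl on this carbonyl carbon gives steps beyond the scatter from both earlier amides: a 2.1-fold lower number from compound 1 to compound 3 (0.33 log units; beyond the scatter) and a 3.6-fold lower number from compound 2 to compound 3 (0.56 log units; beyond the scatter). The number at this position therefore does respond to the group on the carbonyl carbon, which the pair of compound 1 and compound 2 did not show, and the aromatic (4-methylphenyl)amino and the aliphatic (2-(pyrrolidin-1-yl)ethyl)amino both stand on the higher side of compound 3. No measurement shown accounts for this step.

Compound 3 differs from both earlier compounds in lacking the amide hydrogen and in carrying the morpholine ring, and these two differences remain unseparated. Piperidin-1-yl on the same carbonyl carbon would test the ring oxygen, and methyl(4-methylphenyl)amino would test the amide hydrogen.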